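The compounds below may be only part of what the source reports. "The series", "measured", "known", "first", "only" and "open" are said of these compounds alone.

Compound 1 `CCCCCCCc1cc2c(=O)n(CC#N)cnc2s1`: > 100 ug/mL
Compound 2 `CCCCCCCCCCc1cc2c(=O)n(CCO)cnc2s1`: > 100 ug/mL

In an ADME assay on A549 cells (Homo sapiens) for cytotoxicity, read by MTT assay, with a stated time of 11 days (a higher number here means a weaker inhibitor of growth, a lower number a stronger inhibitor of growth), compound 1 reaches only a limit, > 100 ug/mL. Compound 2 likewise stops at a limit, > 100 ug/mL. Within the data shown here, both measured values sit at the limit of > 100 ug/mL in this assay, at which 2 of the 2 values shown sit, so no measured step between them can be read. Compound 3 `CCCCCCCc1cc2c(=O)n(CCN=[N+]=[N-])cnc2s1` is the next compound to be tested; it differs from compound 1 by azidomethyl in place of cyano on a saturated chain carbon bound to an aromatic nitrogen. With the shared core unchanged and both known values at the same limit, the estimated step that the limit leaves unreadable from compound 1 to compound 3 is none beyond the scatter. Compound 3 is expected to give 150 ug/mL in this assay, within 50 ug/mL to 400 ug/mL.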

Compound 3, concentration for 50% growth inhibition: > 100 ug/mL
Compound 3: only a limit was reported; the forecaster's own chance of this, stated with the estimate: 75%; the middle value lies beyond the limit too.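

No step from compound 1 to compound 3 can be read, because both results are limits rather than numbers: the limit of > 100 ug/mL in this assay, at which 3 of the 3 values shown sit.

The compounds shown leave open how strongly any of them inhibits growth, and whether azidomethyl in place of cyano changes that.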